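Chalcone series: thiophen-2-yl in place of 3-fluorophenyl

The source may hold more compounds than are shown below. What is called first, only, known or untested is meant among the compounds shown, and "the series" means these compounds.

Working notes on three chalcones sharing one core. In a functional assay on HCT-116 cells (Homo sapiens) for antiproliferative activity, read by MTT assay, with a stated time of 24 h (on this read-out lower numbers stand for stronger inhibition and higher numbers for weaker inhibition), compound 1 `COc1ccc(C(=O)/C=C/c2cc(OC)c(OC)c(OC)c2)c2c1C=CC(C)(C)O2` gives 7650 nM. Compound 2 `COc1ccc(C(=O)/C=C/c2cccc(F)c2)c2c1C=CC(C)(C)O2` gives in this assay only a limit, > 10000 nM. Compound 3 `COc1ccc(C(=O)/C=C/c2cccc3ccccc23)c2c1C=CC(C)(C)O2` also gives only a limit in this assay, > 10000 nM. Among the measured compounds shown here, compound 2 therefore stands at the limit of > 10000 nM in this assay, at which 2 of the 3 values shown sit, and no measured pair in the set differs in a single place, so no step size is available from the data.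

Compound 4 `COc1ccc(C(=O)/C=C/c2cccs2)c2c1C=CC(C)(C)O2` is not yet measured in this assay. It differs from compound 2 by thiophen-2-yl in place of 3-fluorophenyl on a double-bonded chain carbon bound to a double-bonded chain carbon.

Expectation: compound 1 at 7650 nM is the only numeric value in the set. Two of the three values shown are limits of this assay, so no direction is expected beyond the scatter, and the estimate for compound 4 assumes it most likely remains at or close to the limit. The step that this expectation implies is a step that the limit leaves unreadable from compound 2 to compound 4, stated as an estimate only. Compound 4 is estimated at 12000 nM, within 5000 nM to 30000 nM.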

Compound 4, half-maximal inhibitory concentration: > 10000 nM
Compound 4 ended at the assay's limit (the forecaster's own chance of this, stated with the estimate: 55%); the middle value is on the limit's open side.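

In this assay compound 2 and compound 4 each give only a limit, so no step can be read between them: the limit of > 10000 nM in this assay, at which 3 of the 4 values shown sit.

The compounds shown leave open whether thiophen-2-yl in place of 3-fluorophenyl changes antiproliferative activity on the shared core at all.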